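Trimming a Side Chain by One Carbon

A few compounds are considered here, and "the series" means these few. Any claim that something is new, unique, unknown or untested is made for them only; others in the source may bear on it.

Of the compounds shown here, two have been measured in an in vitro functional assay on cells for agonist activity at Bombesin receptor subtype-3 (Mus musculus), read by luminescence and calcium flux; a lower number here means that less compound is needed, a higher number that more compound is needed for the effect. Compound 1 `O=C(O)c1ccccc1-c1ccc(CCc2ncc(Cc3ccc(Cl)cc3)[nH]2)cc1` gives 102 nM, and compound 2 `CC(C)(C)Cc1cnc(CCc2ccc(-c3ccccc3C(=O)O)cc2)[nH]1` gives 6.3 nM. Compound 2 holds the lower of the two numbers; the step from compound 1 to compound 2 is a 16-fold lower number from compound 1 to compound 2 (1.21 log units; beyond the scatter), which came from putting tert-butyl in place of 4-chlorophenyl on a saturated chain carbon bound to an aromatic carbon.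

Compound 3 `CC(C)(C)c1cnc(CCc2ccc(-c3ccccc3C(=O)O)cc2)[nH]1` differs from compound 2 in one place: tert-butyl in place of neopentyl on an aromatic carbon. The neopentyl group loses its chain carbon, and the tert-butyl group then sits directly on the ring.

Among the measured compounds shown here, no measured step makes this same change. For the measured compounds named here, the only measured step, from compound 1 to compound 2, altered the group hanging from that chain carbon rather than removing the carbon, so it shows only that this part of the molecule responds strongly to what is placed there. Going by the values given here, with no closer precedent, compound 3 is expected to give 15 nM, within 4 nM to 60 nM, an estimated change of a 2.4-fold higher number from compound 2 to compound 3 (0.38 log units; beyond the scatter) that may not reach beyond the scatter.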

Compound 3, half-maximal effective concentration: 2750 nM
The estimate for compound 3 lay 180-fold (2.26 log units) below the measured number, outside the stated range (above it).
By their numbers in this assay, from the lowest: compound 2; then compound 1; then compound 3.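

The earlier step showed that this position responds to what hangs from the chain carbon; this result shows that the chain carbon itself matters just as much. In this assay, removing that one carbon from neopentyl gives a 440-fold higher number from compound 2 to compound 3 (2.64 log units; beyond the scatter), a far larger change than the swap of groups on the chain carbon. Placing tert-butyl directly on the ring also falls short of the 4-chlorobenzyl group, with a 27-fold higher number from compound 1 to compound 3 (1.43 log units; beyond the scatter), and nothing available explains why one carbon counts for so much.

Still open, going by these compounds, is whether the chain carbon alone is enough, or whether the branching on it also matters, which an isobutyl group would help to separate from neopentyl. A longer chain, such as 3,3-dimethylbutyl, would show whether the number keeps falling or rises again.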